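Swapping the aryl group on a sulfonamide nitrogen

The compounds below may be only part of what the source reports. "The series", "measured", "known", "first", "only" and "open" are said of these compounds alone.

Compound 1 has the structure `CC(C)CN(c1ccc(F)cc1)S(=O)(=O)c1ccc2c(c1)C(O)CC(C1CCOCC1)O2`. Going by the values given here, in a physicochemical assay for lipophilicity, at pH 7.4 (a lower number here means a more polar compound, a higher number a more lipophilic compound), compound 1 gives 3.39, the lowest of the two numbers measured so far. Compound 2, `CCc1ccc(N(CC(C)C)S(=O)(=O)c2ccc3c(c2)C(O)C[C@@H](C2CCOCC2)O3)cc1`, carries a different aryl group on the same nitrogen and in this assay compound 2 gives 4.12, which sits clearly above compound 1, further than the scatter of repeat measurements.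

The next compound to be measured is compound 3, `CC(C)CN(c1ccccc1C(F)(F)F)S(=O)(=O)c1ccc2c(c1)C(O)CC(C1CCOCC1)O2`. It differs from compound 1 in one place only: 2-(trifluoromethyl)phenyl in place of 4-fluorophenyl on a sulfonamide nitrogen. Among the compounds with values here, no pair of already-measured compounds shows exactly this change, so its effect cannot be read off directly.

Still, a step upward is expected, since the 2-(trifluoromethyl)phenyl group brings three fluorine atoms and three more heavy atoms than the 4-fluorophenyl group it replaces, and the only other variation of this aryl group, in compound 2 with 4.12, also landed above compound 1. The expected step is a number 0.61 log units higher from compound 1 to compound 3 (beyond the scatter), likely beyond the scatter. For compound 3 the estimated value in this assay is 4, with a range from 3.6 to 4.4.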

Compound 3, distribution coefficient: 4.14
Estimate against measurement, compound 3: 0.14 log units below, within the range that was stated.
By their numbers in this assay, from the lowest: compound 1; then compounds 2 and 3 (each within the scatter of the next).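

On a sulfonamide nitrogen, replacing 4-fluorophenyl with 2-(trifluoromethyl)phenyl now has a directly measured size in this assay, giving a number 0.75 log units higher from compound 1 to compound 3 (beyond the scatter) as the result of a change in one place only. Both groups contain one six-membered aromatic ring of carbon only, with 0 hydrogen-bond donors, 0 hydrogen-bond acceptors and no net charge, while 2-(trifluoromethyl)phenyl has more heavy atoms than 4-fluorophenyl, so this position can carry a larger fluorinated aryl group with a measurable shift in the read-out. No available evidence bears on the cause of this step.

This single pair cannot separate the effect of exchanging fluorine for trifluoromethyl from the effect of that group's different place on the ring. On these data alone, how the number would respond to a plain phenyl group, or to an aryl group carrying an amine or a carboxylic acid, also remains open.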